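Aryl-triazole acetamides: chloro in place of ethynyl

A few compounds are considered here, and "the series" means these few. Any claim that something is new, unique, unknown or untested is made for them only; others in the source may bear on it.

Measured so far:
compound 1, `O=C(Cn1cc(-c2ccncc2)nn1)Nc1nccs1`: 2 nM in a functional assay on BMDM cells (Mus musculus, strain C57BL/6) for inhibition, with a stated time of 2 days; a lower number here means a stronger inhibitor, a higher number a weaker inhibitor
compound 2, `Cc1csc(NC(=O)Cn2cc(-c3ccc(Cl)cc3)nn2)n1`: 520 nM in this assay
compound 3, `C#Cc1ccc(-c2cn(CC(=O)Nc3nccs3)nn2)cc1`: > 30000 nM in this assay, a limit of the assay and not a number

Within the data shown here, compound 3 sits at the weak end of the series: its value is only a limit, (the limit of > 30000 nM in this assay, at which 1 of the 3 values shown sits), so its true potency is not known and no step from it can be sized. Compound 4 is `O=C(Cn1cc(-c2ccc(Cl)cc2)nn1)Nc1nccs1`; it differs from compound 3 in one place, (chloro in place of ethynyl on an aromatic carbon). Among the measured compounds shown here, no pair of measured compounds differing in a single place is available, so no measured step guides this change. Compound 2 carries the same chloro group on a core that differs elsewhere and gives 520 nM, which is the nearest pointer. Compound 4 is therefore expected to come in well inside the assay range, as a step of an at least 50-fold lower number from compound 3 to compound 4 (1.69 log units; beyond the scatter) toward stronger inhibition, beyond the scatter. Compound 4 is estimated at 600 nM, within 100 nM to 5000 nM.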

Compound 4, half-maximal inhibitory concentration: 1100 nM
For compound 4 the middle estimate is 1.8-fold (0.26 log units) below the measured one; the measured number falls inside the stated range.
By their numbers in this assay, from the lowest: compound 1; then compound 2; then compound 4. At a limit, above all of these: compound 3.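

Chloro in place of ethynyl on the aromatic carbon brings the series back into the measurable range of this assay, with an at least 27-fold lower number from compound 3 to compound 4 (1.43 log units; beyond the scatter), and this step gives only a minimum size, since compound 3 is a limit and not a number: the limit of > 30000 nM in this assay, at which 1 of the 4 values shown sits.

Hydrogen in place of methyl on an aromatic carbon changes much less, with a 2.1-fold higher number from compound 2 to compound 4 (0.33 log units; beyond the scatter). The largest step that can be sized is 4-chlorophenyl in place of pyridin-4-yl on an aromatic carbon, with a 550-fold higher number from compound 1 to compound 4 (2.74 log units; beyond the scatter), so chloro restores measurable inhibition without approaching compound 1.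

Open, going by these compounds, is whether an amine or a methoxy group in place of chloro would come closer to compound 1. Also open, on these data alone, is whether methyl in place of hydrogen on an aromatic carbon gives a comparable step alongside pyridin-4-yl.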